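A few compounds are considered here, and "the series" means these few. Any claim that something is new, unique, unknown or untested is made for them only; others in the source may bear on it.

In an ADME assay on NHDF cells (Homo sapiens) for cytotoxicity, read by MTT assay, with a stated time of 72 h (a lower number here means a stronger inhibitor, a higher number a weaker inhibitor), compound 1 `COc1cccc(/C=C2\CCC/C(=C\c3ccccc3Br)C2=O)c1OC` returns > 50000 nM as a limit of the assay and not as a number. Compound 1 thus stands at the limit of > 50000 nM in this assay, at which 1 of the 3 values shown sits, among the readings so far. Compound 4 `COc1cccc(/C=C2\CCC/C(=C\c3cccc(Cl)c3Cl)C2=O)c1OC` carries 2,3-dichlorophenyl in place of 2-bromophenyl on a double-bonded chain carbon bound to a double-bonded ring carbon. The change 2,3-dichlorophenyl in place of 2-bromophenyl on a double-bonded chain carbon bound to a double-bonded ring carbon leaves the rest of compound 1 as it is. Compound 2 `COc1cccc(/C=C2\CCC/C(=C\c3cccc(Br)c3)C2=O)c1OC` and compound 3 `COc1ccc(/C=C2\CCC/C(=C\c3cccc(OC)c3OC)C2=O)cc1` differ at that same place, and three measured steps bear on the question. One is an at least 2.0-fold lower number from compound 1 to compound 2 (0.32 log units; beyond the scatter) and it clears the scatter. Another is an at least 1.1-fold lower number from compound 1 to compound 3 (0.06 log units; that floor lies within the scatter) and its floor does not clear it. The third is a 1.8-fold higher number from compound 2 to compound 3 (0.26 log units; within the scatter) and it stays within the scatter. With compound 2 at 23900 nM and compound 3 at 43500 nM as the nearest readings, a modest move toward lower numbers is expected for compound 4 in this assay rather than a large one. Compound 4 could also return only a limit. The expected step is an at least 1.5-fold lower number from compound 1 to compound 4 (0.18 log units; that floor lies within the scatter) and it may not clear the scatter. Compound 4 is estimated at 33000 nM with 16000 nM to 60000 nM as the expected range.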

Compound 4, half-maximal inhibitory concentration: > 50000 nM
Compound 4: no number, only a limit; the forecaster's own chance of this, stated with the estimate: 35%; middle value at least 1.5-fold (0.18 log units) from the limit.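

In this assay, compound 4 ends at a limit of the assay and not at a number, so 2,3-dichlorophenyl on a double-bonded chain carbon bound to a double-bonded ring carbon leaves it in the same place as compound 1, which carries 2-bromophenyl: the limit of > 50000 nM in this assay, at which 2 of the 4 values shown sit. The step between these two compounds cannot be read, as both values are limits, so the change has no measurable size here. The new compound does sharpen the position of 3-bromophenyl, with an at least 2.0-fold higher number from compound 2 to compound 4 (0.32 log units; beyond the scatter), while an at least 1.1-fold higher number from compound 3 to compound 4 (0.06 log units; that floor lies within the scatter), so only the first of these steps separates compound 4 from a measured neighbour, and of the three compounds bearing bromine or chlorine, only compound 2 returns a number.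

On these data alone, whether compound 1 and compound 4 truly differ remains open, since neither has a number that would allow the two groups to be ranked. Also open, as far as these compounds go, is how this position would respond to 3-chlorophenyl, which would show whether the reading of compound 2 carries over to chlorine, or to a phenyl bearing an amine or a carboxylic acid.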